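The source may report more compounds than this note shows. Statements on the series, on what has been measured and on what is new or still open speak of the compounds shown alone.

Working notes on the series: in a functional assay on MCF7 cells (Homo sapiens) for inhibition, read by CCK-8 assay, with a stated time of 72 h (on this read-out higher numbers stand for weaker inhibition of growth and lower numbers for stronger inhibition of growth), compound 1 (`C#Cc1cccc(Nc2ncnc3cc(OC)c(OCCCCCCCN/C(=N\C#N)Nc4cccnc4)cc23)c1`) gives 42.1 nM. Going by the values given here, its only measured neighbour, compound 2 (`C#Cc1cccc(Nc2ncnc3cc(OC)c(OCCCCCN/C(=N\C#N)Nc4ccncc4)cc23)c1`), bears pyridin-4-yl on an amine nitrogen and gives 38 nM, within the scatter of compound 1. Compound 3 (`C#Cc1cccc(Nc2ncnc3cc(OC)c(OCCCCCCCN/C(=N\C#N)Nc4ccncc4)cc23)c1`) remains unmeasured and has pyridin-4-yl in place of pyridin-3-yl on an amine nitrogen relative to compound 1: pyridin-4-yl in place of pyridin-3-yl on an amine nitrogen. With only those two values to go on, no step beyond the scatter is expected in this assay, in either direction. The expected step is a 1.1-fold lower number from compound 1 to compound 3 (0.04 log units; within the scatter). For compound 3 the estimated value is 38 nM, with an expected range of 15 nM to 100 nM.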

Compound 3, concentration for 50% growth inhibition: 50.9 nM
The estimate for compound 3 lay 1.3-fold (0.13 log units) below the measured number; the measured number falls inside the stated range.
By their numbers in this assay, from the lowest: compounds 2, 1 and 3 (each within the scatter of the next).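

Pyridin-4-yl in place of pyridin-3-yl on an amine nitrogen gives a 1.2-fold higher number from compound 1 to compound 3 (0.08 log units; within the scatter) in this assay. Going by these compounds alone, this is the first comparison in which only the pyridine attachment changes, as compound 2 also differs in its chain, and on this read-out the two groups are not told apart. No measured evidence bears on why the change leaves the read-out within the scatter.

Still open, from the compounds shown here alone, is whether pyridin-2-yl or a plain phenyl on this nitrogen would also stay within the scatter. Also open, going by these compounds, is how a shorter chain would behave with pyridin-3-yl.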